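The source may report more compounds than this note shows. Statements on the series, on what has been measured and on what is new or still open speak of the compounds shown alone.

Measured compounds:
Compound 1, `FC(F)(F)c1ccc(CN2CCN(Cc3cc(-c4ccc(OCc5ccc(Cl)cc5)cc4)on3)CC2)cc1`, in a functional assay on MCF7 cells (Homo sapiens) for antiproliferative activity, read by sulforhodamine B assay, with a stated time of 72 h (a lower number here means a stronger inhibitor, a higher number a weaker inhibitor), gives 6700 nM.
Compound 2, `N#Cc1cccc(COc2ccc(-c3cc(CN4CCN(Cc5ccc(C(F)(F)F)cc5)CC4)no3)cc2)c1`, gives 800 nM.
Compound 3, `Fc1cccc(COc2ccc(-c3cc(CN4CCN(Cc5ccc(C(F)(F)F)cc5)CC4)no3)cc2)c1`, gives 2500 nM.

Compound 2 has the lowest number of the three and is the strongest inhibitor among them: the step of an 8.4-fold lower number from compound 1 to compound 2 (0.92 log units; beyond the scatter) and the step of a 3.1-fold higher number from compound 2 to compound 3 (0.49 log units; beyond the scatter) both lie beyond the scatter, while the step of a 2.7-fold lower number from compound 1 to compound 3 (0.43 log units; beyond the scatter) places compound 3 in between.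

Compound 4, `N#Cc1cccc(COc2ccc(-c3cc(CN4CCN(c5ccc(F)cc5)CC4)no3)cc2)c1`, differs from compound 2 at one place: 4-fluorophenyl in place of 4-(trifluoromethyl)benzyl on an amine nitrogen in a ring. Within the data shown here, none of the measured steps touches this position. All three of them exchange the group on the saturated chain carbon bound to the aromatic oxygen, and compound 4 keeps that part exactly as in compound 2. The measured data therefore give no direct guide to the size or direction of this step, and a change at an unexplored position could move the number either way.

On that basis compound 4 is expected to give about 1600 nM, with a range of 400 nM to 6500 nM. The step this estimate means, a 2.0-fold higher number from compound 2 to compound 4 (0.30 log units; within the scatter), is expected to be a modest weakening, held with wide uncertainty.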

Compound 4, half-maximal inhibitory concentration: 2400 nM
For compound 4 the middle estimate is 1.5-fold (0.18 log units) below the measured one; measured number inside the range.
By their numbers in this assay, from the lowest: compound 2; then compounds 4 and 3 (each within the scatter of the next); then compound 1.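

Among these compounds, the earlier compounds varied only the group on the saturated chain carbon bound to the aromatic oxygen, so this result is the first to test the amine nitrogen in the six-membered non-aromatic ring with 2 nitrogen. In this assay, replacing 4-(trifluoromethyl)benzyl with 4-fluorophenyl at this nitrogen gives a 3.0-fold higher number from compound 2 to compound 4 (0.48 log units; beyond the scatter), which shows that this position also matters and that the group with fewer heavy atoms does not match the one it replaces in this pair. No measurement at hand explains why the number rises.

This single exchange changes two things at once, removing the benzyl carbon and turning trifluoromethyl into fluoro, so a comparison with 4-fluorobenzyl or 4-(trifluoromethyl)phenyl on the same nitrogen would be needed to tell these changes apart. On these data alone, it also remains open how a different kind of group would behave at this nitrogen, such as an acetyl group or a longer chain ending in a carboxylic acid, and whether the same step would have a similar size with another group on the saturated chain carbon.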